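A few compounds are considered here, and "the series" means these few. Any claim that something is new, unique, unknown or untested is made for them only; others in the source may bear on it.

Measured compounds in a functional assay on KB cells (Homo sapiens) for inhibition, read by sulforhodamine B assay; a higher number here means a weaker inhibitor of growth, a lower number a stronger inhibitor of growth:
compound 1 `c1ccc(-c2ccc(-c3ccc(-c4nc5ccccc5[nH]4)cc3)cc2)cc1` gives 39700 nM
compound 2 `COc1ccc(-c2ccc(-c3ccc(-c4nc5cc(C)ccc5[nH]4)cc3)cc2)cc1OC` gives 2190 nM
compound 3 `COc1ccc(-c2ccc(-c3ccc(-c4nc5ccccc5[nH]4)cc3)cc2)cc1OC` gives 9250 nM

Compound 2 has the lowest of the three numbers, and both steps away from it are beyond the scatter. Within this set two changes are seen. The first, from compound 3 to compound 1, is phenyl in place of 3,4-dimethoxyphenyl on an aromatic carbon and made the step of a 4.3-fold higher number from compound 3 to compound 1 (0.63 log units; beyond the scatter). The second, from compound 3 to compound 2, is methyl in place of hydrogen on an aromatic carbon and is reflected in the step of a 4.2-fold higher number from compound 2 to compound 3 (0.63 log units; beyond the scatter).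

Compound 4 `Cc1ccc2[nH]c(-c3ccc(-c4ccc(-c5ccccc5)cc4)cc3)nc2c1` is not yet measured. It differs from compound 2 by phenyl in place of 3,4-dimethoxyphenyl on an aromatic carbon. For the measured compounds named here, this is the same change as the one from compound 3 to compound 1, and the place lines of the two agree word for word. The two cores differ by the methyl described above. Because the earlier change gave a 4.3-fold higher number from compound 3 to compound 1 (0.63 log units; beyond the scatter), a step of similar size is expected from compound 2 to compound 4, namely a 4.3-fold higher number from compound 2 to compound 4 (0.63 log units; beyond the scatter). Compound 4 is therefore estimated at 9400 nM, most likely between 4000 nM and 22000 nM.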

Compound 4, concentration for 50% growth inhibition: 32100 nM
For compound 4 the middle estimate is 3.4-fold (0.53 log units) below the measured one; measured number above the stated range.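

In this assay, phenyl in place of 3,4-dimethoxyphenyl raised the number on both cores, but the size of the change did not carry over, since on the core bearing the methyl it gave a 15-fold higher number from compound 2 to compound 4 (1.17 log units; beyond the scatter), a larger step than on the core without it: the same change on two cores in this assay, a 4.3-fold higher number (0.63 log units; beyond the scatter) from compound 3 to compound 1 and a 15-fold higher number (1.17 log units; beyond the scatter) from compound 2 to compound 4, 3.4-fold (0.53 log units) apart, beyond the scatter of two such steps. The methyl step did not carry over either, since with phenyl in place it gives a 1.2-fold lower number from compound 1 to compound 4 (0.09 log units; within the scatter), which lies within the scatter, whereas with 3,4-dimethoxyphenyl present it was a real step: the same change on two cores in this assay, a 4.2-fold higher number (0.63 log units; beyond the scatter) from compound 2 to compound 3 and a 1.2-fold higher number (0.09 log units; within the scatter) from compound 4 to compound 1, 3.4-fold (0.53 log units) apart, beyond the scatter of two such steps. The two changes are therefore not independent in this small set, yet a single square of four compounds shows only that they depend on each other here, and neither why they do nor whether this holds elsewhere in the series.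

The compounds shown leave open whether a single methoxy group, a hydroxyl or an amine in place of 3,4-dimethoxyphenyl would also let the methyl lower the number. They also leave open whether an ethyl or a chlorine in place of that methyl would behave the same way.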